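Two Aryl Swaps on One Shared Core

The source may report more compounds than this note shows. Statements on the series, on what has been measured and on what is new or still open speak of the compounds shown alone.

Of the compounds shown here, two built on a shared core have been measured in a functional assay on HepG2 cells (Homo sapiens) for cytotoxicity, read by MTT assay, with a stated time of 48 h; on this read-out higher numbers stand for weaker inhibition and lower numbers for stronger inhibition. Compound 1 `O=C(CSc1nnc(-c2ccncc2)o1)N/N=C/c1ccc([N+](=O)[O-])cc1` carries a 4-nitrophenyl group, and in this assay compound 1 gives 17900 nM. Compound 2 `O=C(CSc1nnc(-c2ccncc2)o1)N/N=C/c1cccc(F)c1` carries a 3-fluorophenyl group instead, and in this assay compound 2 gives 19500 nM. Judging by a 1.1-fold higher number from compound 1 to compound 2 (0.04 log units; within the scatter), the two numbers lie within the usual scatter of one another, so neither compound can be called more or less active than the other; compound 2 simply stands alongside compound 1.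

Compound 3 `O=C(CSc1nnc(-c2ccncc2)o1)N/N=C/c1ccccc1[N+](=O)[O-]` has not yet been measured. It differs from compound 2 as follows: 2-nitrophenyl in place of 3-fluorophenyl on a carbon with a double bond to nitrogen. Going by the values given here, the only measured step that bears on this change, a 1.1-fold higher number from compound 1 to compound 2 (0.04 log units; within the scatter), was within the scatter, and that step also exchanged a nitrophenyl for a fluorophenyl group on the same carbon. Bringing a nitrophenyl group back, now as 2-nitrophenyl, is therefore expected to produce no step beyond the scatter. The number expected for compound 3 is 18000 nM, with a range from 8000 nM to 40000 nM. This corresponds to an expected step of a 1.1-fold lower number from compound 2 to compound 3 (0.03 log units; within the scatter).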

Compound 3, half-maximal inhibitory concentration: 24700 nM
The estimate for compound 3 lay 1.4-fold (0.14 log units) below the measured number; low and high end bracket the measured number.
By their numbers in this assay, from the lowest: compounds 1, 2 and 3 (each within the scatter of the next).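

Placing 2-nitrophenyl on the carbon with a double bond to nitrogen, in place of 3-fluorophenyl, gives a 1.3-fold higher number from compound 2 to compound 3 (0.10 log units; within the scatter) in this assay and so does not separate the two compounds. The more telling comparison is new: compound 1 and compound 3 both carry a nitrophenyl group, so 4-nitrophenyl and 2-nitrophenyl can now be set against each other directly, and that change gives a 1.4-fold higher number from compound 1 to compound 3 (0.14 log units; within the scatter) and also does not separate them. So far, then, three different aryl groups at this place, including two placements of the nitro group, give numbers that cannot be told apart in this assay, and nothing measured here offers an explanation for that.

As far as these compounds go, all three groups are substituted phenyl rings, so it remains open whether a phenyl ring carrying an amine or a carboxylic acid, or a longer chain in place of the ring, would produce a step beyond the scatter. The shared core is also the same throughout, which leaves open how a change anywhere else in the molecule would affect the number.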